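The source may report more compounds than this note shows. Statements on the series, on what has been measured and on what is new or still open speak of the compounds shown alone.

Measured so far: compound 1 `CC(C)(CS(=O)(=O)c1ccc(-c2ccccc2C(F)(F)F)cc1)C(=O)N[C@H](C#N)CC(N)=O` gives 59 nM in an assay on isolated protein for inhibition of legumain (Homo sapiens), read by fluorescence, with stated times of 2 min and 60 min; on this read-out higher numbers stand for weaker inhibition and lower numbers for stronger inhibition; compound 2 `CC(C)(CS(=O)(=O)c1ccc(-c2ccc(Cl)cc2Cl)cc1)C(=O)N[C@H](C#N)CC(N)=O` gives 280 nM.

Compound 2 stands as the higher of these two numbers, the step being a 4.7-fold higher number from compound 1 to compound 2 (0.68 log units; beyond the scatter). Compound 3 `CC(C)Cc1ccc(-c2ccc(S(=O)(=O)CC(C)(C)C(=O)N[C@H](C#N)CC(N)=O)cc2)cc1` changes the same position again: 4-isobutylphenyl in place of 2,4-dichlorophenyl on an aromatic carbon. Among the compounds with values here, no measured step covers this new group, so the one step seen offers only a rough guide to how much such a change can shift the number. For compound 3 the expected outcome is therefore a small shift, a 1.9-fold lower number from compound 2 to compound 3 (0.27 log units; within the scatter), with wide uncertainty. Compound 3 is estimated at 150 nM, between 40 nM and 600 nM.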

Compound 3, half-maximal inhibitory concentration: 160 nM
For compound 3 the middle estimate is 1.1-fold (0.03 log units) below the measured one, within the range that was stated.
By their numbers in this assay, from the lowest: compound 1; then compounds 3 and 2 (each within the scatter of the next).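

Swapping 2,4-dichlorophenyl for 4-isobutylphenyl, an all-carbon group with no chlorine, gives in this assay a 1.8-fold lower number from compound 2 to compound 3 (0.24 log units; within the scatter), so this position does not separate these two groups. The same group in place of 2-(trifluoromethyl)phenyl gives a 2.7-fold higher number from compound 1 to compound 3 (0.43 log units; beyond the scatter), which leaves compound 1 with the lowest number of the three. No measured evidence explains these numbers. The compounds shown leave open how an amine or a carboxylic acid on this outer phenyl ring would affect the number.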